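Swapping Trifluoromethoxy for Trifluoromethyl on the Aromatic Ring

A few compounds are considered here, and "the series" means these few. Any claim that something is new, unique, unknown or untested is made for them only; others in the source may bear on it.

Of the compounds shown here, three sharing one core have been measured in an assay on HEK293 cells for agonist activity at Toll-like receptor 8 (Homo sapiens), read by a luciferase reporter, with a stated time of 6 h; a higher number here means that more compound is needed for the effect, a lower number that less compound is needed. Compound 1 `CCCCNc1nc(N)nc2c1CN(Cc1ccccc1)CC2` gives 0.06 uM. Compound 2 `CCCCNc1nc(N)nc2c1CN(Cc1ccc(OC)cc1)CC2`, which carries a methoxy in place of hydrogen on an aromatic carbon, gives 0.08 uM; the step of a 1.3-fold higher number from compound 1 to compound 2 (0.12 log units; within the scatter) stays within the scatter. Compound 3 `CCCCNc1nc(N)nc2c1CN(Cc1ccc(OC(F)(F)F)cc1)CC2` gives 0.24 uM, the highest of the three numbers, so it needs the most compound for the effect; its nearest neighbour is compound 2, and the gap a 3.0-fold higher number from compound 2 to compound 3 (0.48 log units; beyond the scatter), like the gap a 4.0-fold higher number from compound 1 to compound 3 (0.60 log units; beyond the scatter), lies beyond the scatter.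

Compound 4 `CCCCNc1nc(N)nc2c1CN(Cc1ccc(C(F)(F)F)cc1)CC2` has not yet been measured. It differs from compound 3 by trifluoromethyl in place of trifluoromethoxy on an aromatic carbon. Among the measured compounds shown here, no measured step replaces one such group with another; the two steps that bear on this spot, a 4.0-fold higher number from compound 1 to compound 3 (0.60 log units; beyond the scatter) and a 3.0-fold higher number from compound 2 to compound 3 (0.48 log units; beyond the scatter), both end at compound 3 and both are modest. With nothing pointing firmly in either direction, the expected step of a 1.2-fold lower number from compound 3 to compound 4 (0.08 log units; within the scatter) is small and may well stay within the scatter. Compound 4 is therefore estimated at 0.2 uM, within a range of 0.07 uM to 0.6 uM.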

Compound 4, minimum effective concentration: 0.23 uM
Compound 4: middle estimate off by 1.2-fold (0.06 log units), on the low side; the measured number falls inside the stated range.
By their numbers in this assay, from the lowest: compounds 1 and 2 (each within the scatter of the next); then compounds 4 and 3 (each within the scatter of the next).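

In this assay, taking out the oxygen that joins the fluorinated carbon to the aromatic ring leaves no readable difference, with a 1.0-fold lower number from compound 3 to compound 4 (0.02 log units; within the scatter), so at this place, para to a large group, trifluoromethyl and trifluoromethoxy cannot be told apart. The modest rise seen earlier with trifluoromethoxy now appears with a second group, as shown by a 3.8-fold higher number from compound 1 to compound 4 (0.58 log units; beyond the scatter) and a 2.9-fold higher number from compound 2 to compound 4 (0.46 log units; beyond the scatter), so among these four compounds the two that carry three fluorine atoms both need more compound than the unsubstituted compound 1 and the methoxy compound 2, and no compound here goes against this. Nothing available here explains why these two groups behave alike or why they differ from hydrogen and methoxy.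

As far as these compounds go, with only four compounds, it remains open whether the shared step belongs to fluorine-bearing groups in particular or would also appear with a chlorine atom, a nitrile, an amine or a carboxylic acid at the same place. From the compounds shown here alone, it also remains open whether trifluoromethyl and trifluoromethoxy would still match at other places on the aromatic ring, or on a core with a chain other than the butyl amine.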